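The source may report more compounds than this note shows. Statements on the series, on what has been measured and on what is new or still open speak of the compounds shown alone.

Measured compounds in an assay on HEK293 cells for agonist activity at transient receptor potential cation channel subfamily M member 8 (Homo sapiens), read by fluorescence and calcium flux, with a stated time of 15 min; a higher number here means that more compound is needed for the effect, a lower number that less compound is needed:
- compound 1 `CCN(Cc1cccs1)C(=O)COc1ccc(C)cc1`: 8 nM
- compound 2 `Cc1ccc(OCC(=O)N(Cc2cccs2)c2ccn(C)n2)cc1`: 855 nM
- compound 3 `CCN(Cc1cc[nH]n1)C(=O)COc1ccc(C)cc1`: "not active" (no number reported), no number reported

Compound 1 stands lowest of the two numbers in this assay; its nearest neighbour is compound 2, and the step of a 110-fold higher number from compound 1 to compound 2 (2.03 log units; beyond the scatter) is large and beyond the scatter. That step concerns the group on the amide-type nitrogen, 1-methyl-1H-pyrazol-3-yl in place of ethyl. Compound 3 carries a pyrazolylmethyl in place of the thienylmethyl and gives no number at all.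

Compound 4 `CCc1ccc(OCC(=O)N(CC)Cc2cccs2)cc1` is not yet measured. Relative to compound 1 the change is methyl in place of hydrogen on a saturated chain carbon bound to an aromatic carbon; read one bond further out it is methyl to ethyl. Neither measured step touches this part of the molecule: the step from compound 1 to compound 2 and the entry for compound 3 both alter the substituents on the nitrogen, and leave the aryl ether side unchanged. Within the data shown here, there is thus no measured step that bears directly on the change, and no basis for expecting a step beyond the scatter in this assay in either direction. Compound 4 is therefore expected to sit close to compound 1, with the expected step of a 1.5-fold higher number from compound 1 to compound 4 (0.18 log units; within the scatter) small, and an estimated value of 12 nM (range 3 nM to 50 nM).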

Compound 4, half-maximal effective concentration: 67 nM
The estimate for compound 4 lay 5.6-fold (0.75 log units) below the measured number; the measured number lies above the stated range.
By their numbers in this assay, from the lowest: compound 1; then compound 4; then compound 2.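

In this assay, methyl in place of hydrogen on a saturated chain carbon bound to an aromatic carbon, which reads as methyl to ethyl one bond further out, gives an 8.4-fold higher number from compound 1 to compound 4 (0.92 log units; beyond the scatter). Among these compounds, this is the first measured step away from the amide-type nitrogen, and it shows that this position also affects the read-out: a single added heavy atom moves the number beyond the scatter, towards more compound being needed, while compound 4 still gives a number. No available data explain the size or direction of this step.

With only methyl and ethyl represented at this position, the compounds shown cannot establish a trend, so it remains open whether a longer chain such as propyl or a branched group such as isopropyl would raise the number further. Also open, from the compounds shown here alone, is how the number would respond to a methoxy group or a carboxylic acid at this position, or to a bare hydrogen in place of the methyl of compound 1.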